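The source may hold more compounds than are shown below. What is called first, only, known or untested is meant among the compounds shown, and "the series" means these compounds.

Measured compounds:
Compound 1, `Nc1cc(N)c2nc(-c3ccccc3)c(NCc3ccc(Cl)c(Cl)c3)nc2c1`: in a functional assay on MDA-MB-231 cells (Homo sapiens) for inhibition, read by sulforhodamine B assay, with a stated time of 48 h (on this read-out higher numbers stand for lower toxicity in this test and lower numbers for higher toxicity in this test), compound 1 gives only a limit of the assay, < 100000 nM.
Compound 2, `COc1ccc(CNc2nc3cc(N)cc(N)c3nc2-c2ccccc2)cc1OC`: in this assay compound 2 gives 79400 nM.
Compound 3, `Nc1cc(N)c2nc(-c3ccccc3)c(NCc3ccc(F)cc3)nc2c1`: in this assay compound 3 gives 19500 nM.

Compound 3 has the lowest of the two numbers shown; its nearest neighbour is compound 2, and the step of a 4.1-fold lower number from compound 2 to compound 3 (0.61 log units; beyond the scatter) separates them. The value of compound 1 is a limit (the limit of < 100000 nM in this assay, at which 1 of the 3 values shown sits), so the steps a step that the limit leaves unreadable from compound 1 to compound 2 and a step that the limit leaves unreadable from compound 1 to compound 3 cannot be read. Compound 4, `COc1ccc(CNc2nc3cc(N)cc(N)c3nc2-c2ccccc2)cc1`, differs from compound 3 by methoxy in place of fluoro on an aromatic carbon. For the measured compounds named here, only the step from compound 2 to compound 3 bears on this change: it replaced a methoxy-bearing benzyl with the fluorobenzyl and lowered the number modestly, a 4.1-fold lower number from compound 2 to compound 3 (0.61 log units; beyond the scatter). Compound 4 reverses that direction but carries one methoxy where compound 2 carried two, so a rise in number smaller than that step is expected, a 2.1-fold higher number from compound 3 to compound 4 (0.31 log units; beyond the scatter). Compound 4 is therefore estimated at 40000 nM in this assay, with a range from 15000 nM to 100000 nM.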

Compound 4, concentration lethal to 50% of the cells: 64600 nM
Estimate against measurement, compound 4: 1.6-fold (0.21 log units) below; the range from low to high includes it.
By their numbers in this assay, from the lowest: compound 3; then compounds 4 and 2 (each within the scatter of the next).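

For the compounds shown here, on this aromatic carbon, para to a large group, in this assay, methoxy in place of fluoro gives a 3.3-fold higher number from compound 3 to compound 4 (0.52 log units; beyond the scatter), the first reading of this single change on its own. Taking away the second methoxy gives a 1.2-fold lower number from compound 2 to compound 4 (0.09 log units; within the scatter), so one methoxy and two cannot be told apart here, and the fluoro of compound 3 remains the only group shown that brings the number down. The steps from compound 1 cannot be read: the limit of < 100000 nM in this assay, at which 1 of the 4 values shown sits.

The compounds shown leave open how a hydroxyl, an amine or a longer chain such as ethoxy would read on this carbon. Going by these compounds alone, they also leave open whether chloro alone at this place would follow fluoro or methoxy, since the only chloro compound, compound 1, carries two chloro groups and gives only a limit.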